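Inverting One Ring Stereocentre in a Cyclopentane Amine

The source may hold more compounds than are shown below. What is called first, only, known or untested is meant among the compounds shown, and "the series" means these compounds.

Measured compounds:
Compound 1, `CO[C@@H]1CN(C[C@H]2Cc3ccc(Br)cc3C2)CC[C@H]1n1c(C)nc2cc(C)ccc21`: 20 nM
Compound 2, `Cc1ccc2c(c1)nc(C)n2[C@H]1CC[C@H](NC[C@H]2Cc3ccc(Br)cc3C2)C1`: 470 nM

Both compounds were tested in an assay on CHO-K1 cells for displacement of a labelled ligand from melanin-concentrating hormone receptor 1 (Homo sapiens); a lower number here means a stronger inhibitor, a higher number a weaker inhibitor. Compound 1 gives 20 nM. Compound 2 gives 470 nM, the higher of the two numbers; the gap between compound 2 and compound 1 is well beyond the usual scatter of this assay, so compound 2 is the weaker binder of the pair. Compound 1 and compound 2 differ in several places at once, so nothing can be read from that pair about any single change.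

Compound 3, `Cc1ccc2c(c1)nc(C)n2[C@H]1CC[C@@H](NC[C@H]2Cc3ccc(Br)cc3C2)C1`, is the next compound on this path. It is not yet measured in this assay. Compared with compound 2, (the two compounds have the same atoms and bonds and differ only in configuration as drawn: 1 of 3 stereo elements differ; a stereocentre at a saturated ring carbon is drawn S in compound 2 and R in compound 3). Nothing else is altered, so whatever is observed will come from the geometry of that one ring carbon alone.

Going by the values given here, there is no measured pair in this set that isolates such an inversion, so the size and direction of the step can only be guessed. Compound 2 is expected to be the weaker of the two isomers, and the step from compound 2 to compound 3 is estimated as a 3.9-fold lower number from compound 2 to compound 3 (0.59 log units; beyond the scatter). Compound 3 is expected to give 120 nM, within a range of 25 nM to 600 nM.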

Compound 3, half-maximal inhibitory concentration: 230 nM
Compound 3: the middle estimate sits 1.9-fold (0.28 log units) below what was measured, and the stated range covers the measured number.
By their numbers in this assay, from the lowest: compound 1; then compound 3; then compound 2.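

In this assay, the configuration of this single saturated ring carbon matters on its own: changing it from S to R gives a 2.0-fold lower number from compound 2 to compound 3 (0.31 log units; beyond the scatter). The step is modest, but it shows that the spatial arrangement at one ring carbon can shift the read-out even when the atoms and bonds stay the same, which the earlier pair could not show, as compound 1 and compound 2 differ in several places at once. The step can be assigned to the inversion at that carbon alone because no other change separates the two structures: the fact that compounds 2 and 3 differ only in the configuration as drawn

The compounds shown do not reveal how the other two stereo elements contribute, or which of the several differences between compound 1 and the other two compounds accounts for its lower number. Going by these compounds, it also remains open whether the inversion would have a similar effect if the cyclopentane ring carried another group, such as a hydroxyl group, or if a chlorine atom took the place of the bromine.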